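Swapping the Amine End of a Side Chain on Two Cores

A few compounds are considered here, and "the series" means these few. Any claim that something is new, unique, unknown or untested is made for them only; others in the source may bear on it.

Of the compounds shown here, three have been measured in a functional assay on HCT-8 cells (Homo sapiens) for antiproliferative activity, read by MTT assay, with a stated time of 48 h; a lower number here means a stronger inhibitor, a higher number a weaker inhibitor. Compound 1 `CCNCC(=O)Nc1cc(OC)ccc1C(=O)c1ccc(OC)c2c1OC(C)(C)C=C2` gives 3690 nM in this assay. Compound 3 `COc1ccc(C(=O)c2ccc(OC)c3c2OC(C)(C)C=C3)c(NC(=O)CN(C)C)c1` differs from compound 1 in a single place, (dimethylamino in place of ethylamino on a saturated chain carbon bound to a carbonyl carbon), and in this assay compound 3 gives 1590 nM; that change produced a 2.3-fold lower number from compound 1 to compound 3 (0.37 log units; beyond the scatter). Compound 2 `CCNCC(=O)Nc1cc(OC)ccc1C(=O)c1ccc2c(c1)C=CC(C)(C)O2` is built on a different core; the difference between the two cores is not broken down here. In this assay compound 2 gives 3990 nM, a number that sits within the usual scatter of the number for compound 1.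

Compound 4 `COc1ccc(C(=O)c2ccc3c(c2)C=CC(C)(C)O3)c(NC(=O)CN(C)C)c1` has not yet been measured. It stands to compound 2 exactly as compound 3 stands to compound 1: dimethylamino in place of ethylamino on a saturated chain carbon bound to a carbonyl carbon. The place of the change reads the same in both pairs, so this is the same change, not merely the same kind. Going by the values given here, since the only measured example of it is a 2.3-fold lower number from compound 1 to compound 3 (0.37 log units; beyond the scatter), a step of roughly the same size is expected here, namely a 2.2-fold lower number from compound 2 to compound 4 (0.35 log units; beyond the scatter). Compound 4 is therefore estimated at 1800 nM, with a likely range from 900 nM to 3600 nM. The estimate rests on one pair alone, so it is a loose one.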

Compound 4, half-maximal inhibitory concentration: 2420 nM
Beside the measured number, compound 4's estimate is 1.3-fold (0.13 log units) below it; low and high end bracket the measured number.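

On the second core, dimethylamino in place of ethylamino gives a 1.6-fold lower number from compound 2 to compound 4 (0.22 log units; within the scatter) in this assay, so this step taken alone cannot be told apart from the differences seen among repeated measurements. Set side by side, the two steps match as far as these measurements can tell, so the change carries over from one core to the other with no detectable difference in size: the same change on two cores in this assay, a 2.3-fold lower number (0.37 log units; beyond the scatter) from compound 1 to compound 3 and a 1.6-fold lower number (0.22 log units; within the scatter) from compound 2 to compound 4, 1.4-fold (0.15 log units) apart, within the scatter of two such steps

Going by these compounds alone, this does not show that the change reliably lowers the number on the core of compound 2, and with one pair on each of only two cores, it says nothing about any other core or about why the number moves.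

The compounds shown carry only ethylamino and dimethylamino at this end of the side chain, so a ring amine such as morpholine or piperidine, or a plain primary amine, remains an open case. From the compounds shown here alone, a longer chain carrying the amine is equally open, as is whether any such group would give a number far from those seen here.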